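The source may report more compounds than this note shows. Statements on the series, on what has been measured and on what is new or still open speak of the compounds shown alone.

Measured so far:
- compound 1 `Oc1ccc(NC(=S)Nc2ccc3ncnc(Nc4cccc(Br)c4)c3c2)cc1`: 17300 nM
- compound 2 `O=S(=O)(Nc1nccs1)c1ccc(NC(=S)Nc2ccc3ncnc(Nc4cccc(Br)c4)c3c2)cc1`: > 30000 nM
- compound 3 `Fc1ccc(NC(=S)Nc2ccc3ncnc(Nc4cccc(Br)c4)c3c2)cc1Cl`: 300 nM

All three values come from a functional assay on MDA-MB-231 cells (Homo sapiens) for inhibition, read by MTT assay, with a stated time of 48 h; a higher number here means a weaker inhibitor of growth, a lower number a stronger inhibitor of growth. The entry for compound 2 is a limit of the assay, not a number. Compound 3 holds the lower of the two true numbers, after a 58-fold lower number from compound 1 to compound 3 (1.76 log units; beyond the scatter).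

Compound 4 `FC(F)(F)c1ccc(NC(=S)Nc2ccc3ncnc(Nc4cccc(Br)c4)c3c2)cc1` carries 4-(trifluoromethyl)phenyl in place of 3-chloro-4-fluorophenyl on an amide-type nitrogen. The step at this same place is a 58-fold lower number from compound 1 to compound 3 (1.76 log units; beyond the scatter), and it is large. The other step, an at least 1.7-fold higher number from compound 1 to compound 2 (0.23 log units; that floor lies within the scatter), gives only a floor within the scatter. The entering group resembles the 3-chloro-4-fluorophenyl of compound 3 more than the 4-hydroxyphenyl of compound 1, as both carry fluorine on a phenyl ring, so most of that large step should be kept.

The estimated change is a 2.7-fold higher number from compound 3 to compound 4 (0.43 log units; beyond the scatter), a modest rise in the number. For compound 4 the expected value is 800 nM, with an estimated range of 200 nM to 4000 nM.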

Compound 4, concentration for 50% growth inhibition: 12200 nM
Estimate against measurement, compound 4: 15-fold (1.18 log units) below, and the stated range ends below it.
By their numbers in this assay, from the lowest: compound 3; then compounds 4 and 1 (each within the scatter of the next). At a limit, above all of these: compound 2.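

In this assay, the group on the amide-type nitrogen remains decisive: a 41-fold higher number from compound 3 to compound 4 (1.61 log units; beyond the scatter), so fluorine on the phenyl ring does not by itself carry the low number of compound 3. Hydroxy and trifluoromethyl are not told apart: a 1.4-fold lower number from compound 1 to compound 4 (0.15 log units; within the scatter). Compound 2 gives a limit, not a number, so an at least 2.4-fold lower number from compound 2 to compound 4 (0.39 log units; beyond the scatter) is only a floor, and nothing shown accounts for the gap between compound 3 and compound 4.

Open, as far as these compounds go, is whether the chlorine or the fluorine of 3-chloro-4-fluorophenyl matters more. Also open, from the compounds shown here alone, is how a phenyl carrying an amine or a carboxylic acid on this nitrogen would read.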